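Ester-to-amide step on the isopropyl terminus of compound 1

The compounds below may be only part of what the source reports. "The series", "measured", "known", "first", "only" and "open" are said of these compounds alone.

Measured compounds:
compound 1, `CC(/C=C/CC(C)CCCC(C)C)=C\C(=O)OC(C)C`, 7.15
compound 2, `COC(CCC(C)C/C=C/C(C)=C/C(=O)OC(C)C)C(C)C`, 5.95
compound 3, `CC(C)=CCCC(C)C/C=C/C(C)=C/C(=O)OC(C)C`, 6.6

In a physicochemical assay for lipophilicity (a higher number here means a more lipophilic compound, a lower number a more polar compound), compound 1 gives the highest of the three numbers. Its nearest neighbour is compound 3, reached by a number 0.55 log units lower from compound 1 to compound 3 (beyond the scatter); the furthest is compound 2, reached by a number 1.20 log units lower from compound 1 to compound 2 (beyond the scatter). Between the other two, a number 0.65 log units higher from compound 2 to compound 3 (beyond the scatter).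

Compound 4, `CC(/C=C/CC(C)CCCC(C)C)=C\C(=O)NC(C)C`, is not yet measured. It differs from compound 1 in one place: isopropylamino in place of isopropoxy on a carbonyl carbon. Cut one bond further out, the same difference reads isopropoxycarbonyl to isopropylcarbamoyl.

Within the data shown here, none of the measured steps touches the carbonyl carbon; all three alter the saturated chain. The measured steps therefore give no direct guide, and the expectation rests only on the counted difference, which removes one hydrogen-bond acceptor and brings in one hydrogen-bond donor. A step well beyond the scatter, downward, is expected: a number 1.25 log units lower from compound 1 to compound 4 (beyond the scatter). For compound 4 the estimate in this assay is 5.9, with a range from 5.2 to 6.6.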

Compound 4, partition coefficient: 5.65
Compound 4: middle estimate off by 0.25 log units, on the high side; low and high end bracket the measured number.
By their numbers in this assay, from the lowest: compounds 4 and 2 (each within the scatter of the next); then compound 3; then compound 1.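

In this assay, the carbonyl carbon is shown to be a position where a single change gives a number 1.50 log units lower from compound 1 to compound 4 (beyond the scatter) for isopropylamino in place of isopropoxy, whereas the earlier steps all altered the saturated chain. Both groups have 4 heavy atoms, so this large step comes with an equal heavy-atom count: oxygen gives way to nitrogen, 1 hydrogen-bond acceptor leaves and 1 hydrogen-bond donor enters.

Still open, on these data alone, is how a dimethylamino group, which would carry no amide hydrogen, or a carboxylic acid on the same carbonyl carbon would read in this assay against compound 1 and compound 4. Also open, as far as these compounds go, is whether the same ester-to-amide change gives a step of similar size on the chains of compound 2 and compound 3. No supporting measurement on hand bears on the origin of the step.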